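Bulkier Amine on a Shorter Chain: Compound 4 Expected

The source may report more compounds than this note shows. Statements on the series, on what has been measured and on what is new or still open speak of the compounds shown alone.

Compound 3 `Cc1cccc2sc(NC(=O)CCN3CCN(CCCN(C)C)CC3)nc12` belongs to a set of three relatives that share one core and differ only in the group attached to the ring amine nitrogen. In an assay on membranes from liver for displacement of a labelled ligand from Sigma intracellular receptor 2 (Rattus norvegicus), read by scintillation counting, with a stated time of 120 min (on this read-out lower numbers stand for stronger inhibition and higher numbers for weaker inhibition), compound 3 gives > 1000 nM, which is a limit of the assay rather than a number (the limit of > 1000 nM in this assay, at which 1 of the 3 values shown sits). Compound 1 `Cc1cccc2sc(NC(=O)CCN3CCN(C(C)C)CC3)nc12` gives 1800 nM, and compound 2 `Cc1cccc2sc(NC(=O)CCN3CCN(C(C)(C)C)CC3)nc12` gives 200 nM. The step of a 9.0-fold lower number from compound 1 to compound 2 (0.95 log units; beyond the scatter) went with a change from isopropyl to tert-butyl, whereas an at least 5.0-fold higher number from compound 2 to compound 3 (0.69 log units; beyond the scatter) went with tert-butyl giving way to 3-(dimethylamino)propyl. Compound 4 `Cc1cccc2sc(NC(=O)CCN3CCN(CCN(C(C)C)C(C)C)CC3)nc12` differs from compound 3 by diisopropylamino in place of (dimethylamino)methyl on a saturated chain carbon, two bonds along the chain from an amine nitrogen in a ring. Since only a limit is known for compound 3, the direction of an at least 1.2-fold lower number from compound 3 to compound 4 (0.09 log units; that floor lies within the scatter) is an expectation resting on the one measured gain. Compound 4 is estimated at 800 nM, within a range of 200 nM to 3000 nM.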

Compound 4, inhibition constant: 121 nM
Compound 4: the middle estimate sits 6.6-fold (0.82 log units) above what was measured; the whole stated range lies above it.
By their numbers in this assay, from the lowest: compounds 4 and 2 (each within the scatter of the next); then compound 1.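

On the ring amine nitrogen, a chain carrying an amine does not always sit poorly in this assay: 2-(diisopropylamino)ethyl in place of 3-(dimethylamino)propyl gives an at least 8.2-fold lower number from compound 3 to compound 4 (0.91 log units; beyond the scatter). That chain also matches tert-butyl, with a 1.7-fold lower number from compound 2 to compound 4 (0.22 log units; within the scatter), and clearly outdoes isopropyl, with a 15-fold lower number from compound 1 to compound 4 (1.17 log units; beyond the scatter). The reading for compound 3 is a limit of the assay, not a number: the limit of > 1000 nM in this assay, at which 1 of the 4 values shown sits.

Chain and amine change together between compound 3 and compound 4, so the compounds shown do not tell which change carries the gain. A 2-(dimethylamino)ethyl or a 3-(diisopropylamino)propyl group at this nitrogen would separate the two.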